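This account rests on a few compounds, and the source may have more. Where it says the series, first, only, none or still open, it means among the compounds named here.

Among the measured compounds shown here, compound 1, `CC#C[C@H]1CN(S(=O)(=O)c2ccc(N)nc2)CCN1c1ccc(C(O)(CC#N)C(F)(F)F)cc1`, is one of three compounds measured in an assay on isolated protein for inhibition of glucokinase regulatory protein (Homo sapiens), read by AlphaScreen, with stated times of 20 min and 4 h (a higher number here means a weaker inhibitor, a lower number a stronger inhibitor), and in this assay compound 1 gives 28 nM. It stands second highest of the three numbers: compound 3, `CC#C[C@H]1CN(S(=O)(=O)c2ccc(N)nc2)CCN1c1ncc(C(O)(C(F)(F)F)C(F)(F)F)cn1`, gives 10 nM in this assay, a lower number that lies beyond the scatter of the measurement, while compound 2, `CC#C[C@H]1CN(S(=O)(=O)c2ccc(N)nc2)CCN1c1ncc(C(O)(C(F)(F)F)C(F)(F)F)s1`, gives 81 nM in this assay, a higher number that also lies beyond the scatter. For the measured compounds named here, the three compounds differ from one another in more than one place, so no single step between measured compounds is available.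

The step of interest leads from compound 1 to compound 4, `C#CCC(O)(c1ccc(N2CCN(S(=O)(=O)c3ccc(N)nc3)C[C@@H]2C#CC)cc1)C(F)(F)F`, which has not yet been measured in this assay. The difference is ethynyl in place of cyano on a saturated chain carbon, two bonds along the chain from an aromatic carbon and an oxygen on a saturated carbon. Neither the cyano nor the ethynyl occurs elsewhere among the measured compounds, so the measured numbers give no direct guide to the direction of this step. Compound 4 is therefore expected to land close to compound 1, with a step of a 1.1-fold higher number from compound 1 to compound 4 (0.03 log units; within the scatter) that need not exceed the scatter in either direction. The estimate for compound 4 in this assay is 30 nM, with a range from 12 nM to 75 nM.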

Compound 4, half-maximal inhibitory concentration: 6 nM
For compound 4 the middle estimate is 5.0-fold (0.70 log units) above the measured one, outside the stated range (below it).
By their numbers in this assay, from the lowest: compounds 4 and 3 (each within the scatter of the next); then compound 1; then compound 2.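

In this assay the change to ethynyl in place of cyano on a saturated chain carbon, two bonds along the chain from an aromatic carbon and an oxygen on a saturated carbon, gives a 4.7-fold lower number from compound 1 to compound 4 (0.67 log units; beyond the scatter) and this modest step lies beyond the scatter. Among the compounds shown here, the earlier compounds carry neither group, so this is the first reading at this position, and it shows that the cyano and the hydrogen-bond acceptor counted for it are not required for inhibition in compound 4. Nothing measured here explains why the number falls, so the step stands as an observation only.

Going by these compounds, it remains open whether the step depends on the triple bond or on the ethynyl group itself, since a saturated propyl chain, a longer butynyl chain or an amine at this position could separate those readings. On these data alone, it is also open whether cyanomethyl to propargyl would have a similar effect on the different cores of compound 2 and compound 3.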